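Methoxy for fluoro on the pyrrole-side phenyl ring

The source may report more compounds than this note shows. Statements on the series, on what has been measured and on what is new or still open speak of the compounds shown alone.

Compound 2 `CC(=O)c1cc(-c2ccccc2)cc2cc(-c3ccc(F)cc3)[nH]c12` is the starting point. Going by the values given here, in a functional assay on HeLa cells (Homo sapiens) for cytotoxicity, read by MTT assay, with a stated time of 2 days, tested at 10 uM (a higher number here means a weaker effect of the compound at the concentration tested, a lower number a stronger effect), compound 2 gives 76.9%, the highest of the three numbers measured so far. Compound 1 `CC(=O)c1cc(-c2ccccc2)cc2cc(-c3ccccc3)[nH]c12` gives 60.9% and compound 3 `COc1ccc(-c2cc(C(C)=O)c3[nH]c(-c4ccc(F)cc4)cc3c2)cc1` gives 46.5%, both beyond the scatter below compound 2. Compound 4 `COc1ccc(-c2cc3cc(-c4ccccc4)cc(C(C)=O)c3[nH]2)cc1` has not yet been measured; its change from compound 2 is methoxy in place of fluoro on an aromatic carbon.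

Among the compounds with values here, two measured steps bear on this. Adding a fluoro to the same ring raised the number: a number 16 percentage points higher from compound 1 to compound 2 (beyond the scatter), a modest step. Adding a methoxy, though to the other phenyl ring, lowered it strongly: a number 30.4 percentage points lower from compound 2 to compound 3 (beyond the scatter). Compound 4 both loses the fluoro and gains a methoxy, so on this evidence a step downward in this assay is expected, likely larger than the scatter, though the methoxy sits on a different ring than in compound 3, which weakens the parallel. The expected step is a number 34.9 percentage points lower from compound 2 to compound 4 (beyond the scatter). Compound 4 is therefore estimated at 42%, within a range of 22% to 64%.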

Compound 4, a percentage reported as activity, at one concentration (the size of the read-out at that concentration, not a potency): 51.6%
Compound 4: middle estimate off by 9.6 percentage points, on the low side; the range from low to high includes it.
By their numbers in this assay, from the lowest: compounds 3, 4 and 1 (each within the scatter of the next, the first and the last beyond it); then compound 2.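

In this assay, going by these compounds alone, 4-methoxyphenyl in place of 4-fluorophenyl gives a number 25.3 percentage points lower from compound 2 to compound 4 (beyond the scatter), the first direct comparison of these two groups at this position. Against the unsubstituted ring the same methoxy gives a number 9.3 percentage points lower from compound 1 to compound 4 (within the scatter), so methoxy and hydrogen cannot be told apart here, and among these three substituents it is fluoro that stands apart. Methoxy in place of hydrogen therefore does not read the same on the two cores, and the strong effect seen with compound 3 does not carry over to this position: the same change on two cores in this assay, a number 30.4 percentage points lower (beyond the scatter) from compound 2 to compound 3 and a number 9.3 percentage points lower (within the scatter) from compound 1 to compound 4, 21.1 percentage points apart, beyond the scatter of two such steps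

From the compounds shown here alone, whether a chloro, a hydroxyl or an amine at this position would group with fluoro or with methoxy remains open. Each reading is taken at a single concentration, so these differences show only a stronger or weaker effect at that concentration.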